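Replacing a fluorophenyl amide with a cinnamoyl-type amide

This account rests on a few compounds, and the source may have more. Where it says the series, first, only, none or still open, it means among the compounds named here.

Compound 1 `CN1[C@@H]2c3[nH]c4ccccc4c3C[C@H]1[C@H](C#N)N1[C@@H](CNC(=O)c3ccc(F)cc3)c3[nH]c4ccccc4c3C[C@@H]21` is one of three analogues sharing a core and differing only at the group on a carbonyl carbon. In a functional assay on HT-29 cells (Homo sapiens) for cytotoxicity, read by MTT assay, with a stated time of 72 h (on this read-out higher numbers stand for weaker inhibition and lower numbers for stronger inhibition), compound 1 gives 1370 nM. Compound 2 `CN1[C@@H]2c3[nH]c4ccccc4c3C[C@H]1[C@H](C#N)N1[C@@H](CNC(=O)c3cc4ccccc4[nH]3)c3[nH]c4ccccc4c3C[C@@H]21` gives 1220 nM, and the step of a 1.1-fold lower number from compound 1 to compound 2 (0.05 log units; within the scatter). Compound 3 `CN1[C@@H]2c3[nH]c4ccccc4c3C[C@H]1[C@H](C#N)N1[C@@H](CNC(=O)/C=C/c3cccc(C(F)(F)F)c3)c3[nH]c4ccccc4c3C[C@@H]21` gives 5060 nM, with a 3.7-fold higher number from compound 1 to compound 3 (0.57 log units; beyond the scatter) and a 4.1-fold higher number from compound 2 to compound 3 (0.62 log units; beyond the scatter). Compound 1 thus stands second highest of the three numbers, close to compound 2 and well below compound 3. Compound 4 `CN1[C@@H]2c3[nH]c4ccccc4c3C[C@H]1[C@H](C#N)N1[C@@H](CNC(=O)/C=C/c3ccccc3)c3[nH]c4ccccc4c3C[C@@H]21` differs from compound 1 in this way: 2-phenylethenyl in place of 4-fluorophenyl on a carbonyl carbon. The step from compound 1 to compound 3 is the closest guide, since it also introduces an ethenyl-linked aryl group; a weakening of similar size is therefore expected, a 2.6-fold higher number from compound 1 to compound 4 (0.42 log units; beyond the scatter). Compound 4 is estimated at 3600 nM, within 1500 nM to 8500 nM.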

Compound 4, half-maximal inhibitory concentration: 1400 nM
Beside the measured number, compound 4's estimate is 2.6-fold (0.41 log units) above it, and the stated range ends above it.
By their numbers in this assay, from the lowest: compounds 2, 1 and 4 (each within the scatter of the next); then compound 3.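

In this assay, an ethenyl-linked phenyl on the carbonyl carbon does not by itself separate compound 4 from the aryl amides (a 1.0-fold higher number from compound 1 to compound 4 (0.01 log units; within the scatter) and a 1.1-fold higher number from compound 2 to compound 4 (0.06 log units; within the scatter)). The higher number of compound 3 therefore goes with the trifluoromethyl group rather than with the 2-phenylethenyl frame, as hydrogen in its place shows (a 3.6-fold lower number from compound 3 to compound 4 (0.56 log units; beyond the scatter)). Nothing given here accounts for this difference. The compounds shown leave open whether an amine or a carboxylic acid on that aromatic carbon would also move the number. They also leave open whether a saturated chain could stand in place of the ethenyl link.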